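Compound 3 to compound 4: sulfanylmethyl for sec-butyl

A few compounds are considered here, and "the series" means these few. Any claim that something is new, unique, unknown or untested is made for them only; others in the source may bear on it.

compound 1 `COc1cc(-c2nc3ccccc3s2)ccc1OCC(=O)NNC(=O)CN(C(C)=O)[C@@H](CS)C(=O)O` gives 1750 nM
compound 2 `COc1cc(-c2nc3ccccc3s2)ccc1OCC(=O)NNC(=O)CN[C@@H](CCSC)C(=O)O` gives 1950 nM
compound 3 `CCOC(=O)[C@@H](NCC(=O)NNC(=O)COc1ccc(-c2nc3ccccc3s2)cc1OC)[C@@H](C)CC` gives 1950 nM

All three values come from a functional assay on MCF7 cells (Homo sapiens) for inhibition, read by MTT assay, with a stated time of 3 days (a higher number here means a weaker inhibitor, a lower number a stronger inhibitor), and lie within the scatter of one another. Compound 3 stands at 1950 nM and is level with compound 2 at the digits given. The next structure is compound 4 `CCOC(=O)[C@H](CS)NCC(=O)NNC(=O)COc1ccc(-c2nc3ccccc3s2)cc1OC`, which carries sulfanylmethyl in place of sec-butyl on a saturated chain carbon bound to an amine nitrogen and a carbonyl carbon. Among the compounds with values here, three measured steps bear on this change, and each lies within the scatter: a 1.1-fold higher number from compound 1 to compound 3 (0.05 log units; within the scatter), no change at the digits printed from compound 2 to compound 3 (within the scatter) and a 1.1-fold higher number from compound 1 to compound 2 (0.05 log units; within the scatter) on the same stretch of chain. Within the data shown here, none isolates sec-butyl against sulfanylmethyl, and the data hold no pair that does. With so little movement so far, no step beyond the scatter is expected in this assay here. The estimate means a 1.0-fold lower number from compound 3 to compound 4 (0.01 log units; within the scatter) as the expected step. Compound 4 is expected at 1900 nM within an estimated range of 1000 nM to 3600 nM in this assay on these numbers.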

Compound 4, half-maximal inhibitory concentration: 2880 nM
The estimate for compound 4 lay 1.5-fold (0.18 log units) below the measured number; the measured number falls inside the stated range.
By their numbers in this assay, from the lowest: compounds 1, 2, 3 and 4 (each within the scatter of the next).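

In this assay, within the data shown here, sulfanylmethyl in place of sec-butyl on a saturated chain carbon bound to an amine nitrogen and a carbonyl carbon gives a 1.5-fold higher number from compound 3 to compound 4 (0.17 log units; within the scatter), the first direct reading of this change, and it stays within the scatter. The wider replacements read the same way, with a 1.5-fold higher number from compound 2 to compound 4 (0.17 log units; within the scatter) and a 1.6-fold higher number from compound 1 to compound 4 (0.22 log units; within the scatter), so this assay separates none of the four side chains and end groups shown. No measured evidence bears on these steps.

Going by these compounds, whether a phenyl ring, a basic amine or a longer chain on the same carbon would give a step beyond the scatter in this assay remains open. So does the comparison of the ethyl ester with the carboxylic acid on one unchanged side chain.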